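Removing a Methoxy Group from a Compound at the Assay Limit

A few compounds are considered here, and "the series" means these few. Any claim that something is new, unique, unknown or untested is made for them only; others in the source may bear on it.

Three sulfonamides have been tested in a functional assay on MCF7 cells (Homo sapiens) for antiproliferative activity, read by MTT assay, with a stated time of 72 h; on this read-out higher numbers stand for weaker inhibition and lower numbers for stronger inhibition. Within the data shown here, compound 1 (`COc1ncc(-c2ccc3c(c2)N(c2ccc(C)cc2)C(=O)CO3)cc1NS(=O)(=O)c1ccc(F)cc1`) gives 15400 nM, the only exact number so far. Compound 2 (`O=C1COc2ccc(-c3cnc(Cl)c(NS(=O)(=O)c4ccc(F)cc4)c3)cc2N1`) is reported only as a limit, > 40000 nM. Compound 3 (`COc1cccc(N2C(=O)COc3ccc(-c4cccc(NS(=O)(=O)c5ccc(F)cc5)c4)cc32)c1`) is also reported only as a limit, > 40000 nM. Compound 3 thus stands at the limit of > 40000 nM in this assay, at which 2 of the 3 values shown sit.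

Compound 4 (`O=C1COc2ccc(-c3cccc(NS(=O)(=O)c4ccc(F)cc4)c3)cc2N1c1ccccc1`) differs from compound 3 by hydrogen in place of methoxy on an aromatic carbon, so that 3-methoxyphenyl becomes phenyl: hydrogen in place of methoxy on an aromatic carbon. Among the measured compounds shown here, no measured pair shows this change on its own. In this assay, no step beyond the scatter is expected, and a large gain in potency seems unlikely. Compound 1 at 15400 nM shows only that a measurable value is possible among these compounds, so compound 4 may yet give a number rather than a limit. The estimated change is an at least 1.2-fold lower number from compound 3 to compound 4 (0.09 log units; that floor lies within the scatter), which remains tentative. For compound 4 the estimated value is 32000 nM, with an expected range from 12000 nM to 60000 nM.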

Compound 4, half-maximal inhibitory concentration: > 40000 nM
Compound 4 was reported as a limit; the forecaster's own chance of this, stated with the estimate: 55%; middle value at least 1.2-fold (0.09 log units) away from the limit.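

Compound 4 is reported only as a limit in this assay, > 40000 nM. Compound 3 is also only a limit, so no step can be read between compound 3 and compound 4, and both stand at the same limit: the limit of > 40000 nM in this assay, at which 3 of the 4 values shown sit.

The compounds shown leave open what size of change, if any, hydrogen in place of methoxy on an aromatic carbon brings.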